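Plasma stability notes: from compound 1 to compound 3

A few compounds are considered here, and "the series" means these few. Any claim that something is new, unique, unknown or untested is made for them only; others in the source may bear on it.

Measured so far:
compound 1 `CC(C)C(=O)OCOC(=O)C1=C(S[C@@H]2CN[C@H](C(=O)Nc3cccc(C(=O)O)c3)C2)[C@H](C)[C@@H]2[C@@H]([C@@H](C)O)C(=O)N12` gives 0%
compound 2 `CCC(CC)C(=O)OCOC(=O)C1=C(S[C@@H]2CN[C@H](C(=O)Nc3cccc(C(=O)O)c3)C2)[C@H](C)[C@@H]2[C@@H]([C@@H](C)O)C(=O)N12` gives 0%

In an ADME assay on a cell-free system (plasma, Rattus norvegicus) for metabolic stability, read by LC-MS, with a stated time of 60 min, at 37 degrees C, tested at 50 uM (on this read-out lower numbers stand for a less stable compound and higher numbers for a more stable compound), compound 1 gives 0%, the bottom of the read-out, and compound 2 gives 0% in this assay. Among the measured compounds shown here, the one measured step, no change at the digits printed from compound 1 to compound 2 (within the scatter), leaves the read-out where it was. Compound 1 thus stands level with compound 2, with nothing remaining in either case after the stated time.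

Compound 3 `CC(C)C(=O)OCOC(=O)C1=C(S[C@@H]2CN[C@H](C(=O)Nc3cccc(C(=O)OCOC(=O)C(C)C)c3)C2)[C@H](C)[C@@H]2[C@@H]([C@@H](C)O)C(=O)N12` differs from compound 1 by ((isopropylcarbonyl)oxy)methyl in place of hydrogen on an oxygen next to a carbonyl group. The measured step bears on it only loosely: it swaps one chain for another on a carbonyl carbon, whereas here a group of seven heavy atoms enters on an oxygen next to a carbonyl group where a hydrogen stood. Nothing in the series shows any movement away from the bottom of the read-out, so no step beyond the scatter is expected.

For compound 3 the estimate in this assay is 0%, range 0% to 10%, and the expected step is no change at the digits printed from compound 1 to compound 3 (within the scatter), none beyond the scatter.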

Compound 3, percent of the compound remaining: 1%
Compound 3: middle estimate off by 1 percentage points, on the low side; the measured number falls inside the stated range.
By their numbers in this assay, from the lowest: compounds 1, 2 and 3 (each within the scatter of the next).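

In this assay, ((isopropylcarbonyl)oxy)methyl in place of hydrogen on an oxygen next to a carbonyl group gives a number 1 percentage points higher from compound 1 to compound 3 (within the scatter). Compound 2 varied only the chain on a carbonyl carbon, so this is the first change shown at a second site of the series, the carboxy group, which here becomes (((isopropylcarbonyl)oxy)methoxy)carbonyl. The free carboxy group is therefore not required for a reading at this low end of the scale, and adding this group on that oxygen does not lift the reading beyond the scatter. No measurement at hand offers an explanation for this result.

Still open, going by these compounds, is whether any change at either site can bring the reading clear of the low end of the scale, for example a simple methyl ester on that oxygen, or an amine or a longer chain in place of the isopropyl on the carbonyl carbon. A single reading at the stated time also leaves open how quickly each compound disappears, and which parts of the molecule are lost first.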